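A few compounds are considered here, and "the series" means these few. Any claim that something is new, unique, unknown or untested is made for them only; others in the source may bear on it.

Compound 2 `O=C(/C(=C\c1ccc(O)c([N+](=O)[O-])c1)S(=O)(=O)Cc1ccccc1Cl)c1ccc(Cl)cc1` and compound 3 `CCOc1ccc(/C=C(\C(=O)c2ccc(Cl)cc2)S(=O)(=O)Cc2ccccc2Cl)cc1OC` share a core and differ in one place: 4-ethoxy-3-methoxyphenyl in place of 4-hydroxy-3-nitrophenyl on a double-bonded chain carbon bound to a double-bonded chain carbon. In a functional assay on DU-145 cells (Homo sapiens) for inhibition, read by trypan blue exclusion, with a stated time of 96 h (on this read-out higher numbers stand for weaker inhibition of growth and lower numbers for stronger inhibition of growth), compound 2 gives 10000 nM, and compound 3 gives 10000 nM; the step is no change at the digits printed from compound 2 to compound 3 (within the scatter). Compound 1 `Cc1ccc(S(=O)(=O)/C(=C/c2ccc(O)c([N+](=O)[O-])c2)C(=O)c2ccc(Cl)cc2)cc1` arises from compound 2 by 4-methylphenyl in place of 2-chlorobenzyl on a sulfonyl sulfur. In this assay compound 1 gives 25000 nM, so that the step is a 2.5-fold higher number from compound 2 to compound 1 (0.40 log units; beyond the scatter).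

Compound 4 `CCOc1ccc(/C=C(\C(=O)c2ccc(Cl)cc2)S(=O)(=O)c2ccc(C)cc2)cc1OC` has not yet been measured in this assay. It stands to compound 3 as compound 1 stands to compound 2: 4-methylphenyl in place of 2-chlorobenzyl on a sulfonyl sulfur. The place of the change reads the same in both pairs, so it is the same change, here made on the core of compound 3 rather than on that of compound 2. Among these compounds it has been measured once only.

The step expected from this change is a 2.5-fold higher number from compound 3 to compound 4 (0.40 log units; beyond the scatter). The expectation rests on the measured step of a 2.5-fold higher number from compound 2 to compound 1 (0.40 log units; beyond the scatter), taken from a starting value level with that of compound 3, and on the cores differing only by no change at the digits printed from compound 2 to compound 3 (within the scatter). Compound 4 is therefore expected near 25000 nM in this assay, with a likely range from 10000 nM to 60000 nM.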

Compound 4, concentration for 50% growth inhibition: 1000 nM
Compound 4: middle estimate off by 25-fold (1.40 log units), on the high side, outside the stated range (below it).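

In this assay, 4-methylphenyl in place of 2-chlorobenzyl on the sulfonyl sulfur gives a 10-fold lower number from compound 3 to compound 4 (1.00 log units; beyond the scatter), so the change does not carry over from one core to the other in either size or direction: the same change on two cores in this assay, a 2.5-fold higher number (0.40 log units; beyond the scatter) from compound 2 to compound 1 and a 10-fold lower number (1.00 log units; beyond the scatter) from compound 3 to compound 4, 25-fold (1.40 log units) apart, beyond the scatter of two such steps. The outcome of this change is thus tied to the core on which it is made, even though with 2-chlorobenzyl in place the two cores show no change at the digits printed from compound 2 to compound 3 (within the scatter), so a level starting value did not predict the step. Two pairs do not show why the steps differ, nor which direction a third core would follow.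

The compounds shown leave open which part of the two phenyl groups on the double-bonded chain carbon carries the reversal, the hydroxy and nitro groups or the ethoxy and methoxy groups. They also leave open how the step would run on a core with an amine or a carboxylic acid on that phenyl ring.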